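The source may report more compounds than this note shows. Statements on the series, on what has been measured and on what is new or still open speak of the compounds shown alone.

Compound 2 `O=C(Nc1nnc(-c2ccc3c(c2)OCCO3)s1)c1ccccn1` carries a pyridin-2-yl group on the carbonyl carbon of its amide. Going by the values given here, in a functional assay on BGC-823 cells (Homo sapiens) for antiproliferative activity, read by MTT assay, with a stated time of 48 h (on this read-out higher numbers stand for an effect only at larger amounts of compound and lower numbers for an effect already at smaller amounts), compound 2 gives 35.8 ug/mL, the only actual number among the results. Compound 1 `Cc1ccccc1C(=O)Nc1nnc(-c2ccc3c(c2)OCCO3)s1`, with 2-methylphenyl in that place, reaches only the limit of this assay, > 100 ug/mL. The step of an at least 2.7-fold lower number from compound 1 to compound 2 (0.44 log units; beyond the scatter) rests on (the limit of > 100 ug/mL in this assay, at which 1 of the 2 values shown sits). Compound 3 `Cc1ccc(C(=O)Nc2nnc(-c3ccc4c(c3)OCCO4)s2)cn1` is not yet measured; it differs from compound 2 in one place: 6-methylpyridin-3-yl in place of pyridin-2-yl on a carbonyl carbon. Among the compounds with values here, the single measured step shows that exchanging the group on this carbonyl carbon can move the read-out beyond the scatter, but it gives no direct guide to a 6-methylpyridin-3-yl group, which neither measured compound carries. The step of a 1.3-fold higher number from compound 2 to compound 3 (0.10 log units; within the scatter) is therefore expected to stay within the scatter, with wide uncertainty in either direction. Compound 3 is estimated at 45 ug/mL, within 15 ug/mL to 150 ug/mL.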

Compound 3, half-maximal effective concentration: > 100 ug/mL
Compound 3 was reported as a limit; the forecaster's own chance of this, stated with the estimate: 25%; middle value at least 2.2-fold (0.34 log units) away from the limit.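

The earlier step set pyridin-2-yl against 2-methylphenyl, and this one compares two groups that each hold one six-membered aromatic ring with 1 hetero atom: in this assay, the exchange for 6-methylpyridin-3-yl gives an at least 2.7-fold higher number from compound 2 to compound 3 (0.44 log units; beyond the scatter). Carrying such a ring on this carbonyl carbon is therefore not enough in itself to give a measurable value, and among the three compounds only the pyridin-2-yl group does so. The step between compound 1 and compound 3 cannot be read, because both values are limits: the limit of > 100 ug/mL in this assay, at which 2 of the 3 values shown sit.

Compound 3 differs from compound 2 both in its methyl group and in how its ring is attached, so the shown data cannot separate these two changes. As far as these compounds go, a plain pyridin-3-yl group or a 6-methylpyridin-2-yl group would be needed to tell them apart, and how an amine or a carboxylic acid on the ring would behave here remains open.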